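A few compounds are considered here, and "the series" means these few. Any claim that something is new, unique, unknown or untested is made for them only; others in the source may bear on it.

Compound 1, `CC(C)(C)c1ccc(NC(=O)NCCCCl)cc1`, was tested in a functional assay on MCF7 cells (Homo sapiens) for antiproliferative activity, with a stated time of 48 h (a higher number here means a weaker inhibitor, a lower number a stronger inhibitor), and gave 49000 nM. Among the two results in this assay it is the only actual number. Compound 2, `CCCCC(O)c1cccc(NC(=O)NCCCCl)c1`, returned only > 100000 nM in this assay, which is a limit of the measurement rather than a number; (the limit of > 100000 nM in this assay, at which 1 of the 2 values shown sits). Compound 1 therefore stands alone as a measured value, with nothing comparable on either side of it.

Compound 3, `CC(C)(C)c1ccc(NC(=O)CCl)cc1`, has not yet been tested. It differs from compound 1 in one place: chloromethyl in place of (3-chloropropyl)amino on a carbonyl carbon. The carbonyl carbon keeps its amide-type nitrogen, while the (3-chloropropyl)amino group is replaced by the much smaller chloromethyl group. Among the measured compounds shown here, no pair of measured compounds shows what such a change does in this assay, so the direction of the step cannot be read from the data. My expectation is that compound 3 comes out somewhat more potent than compound 1, the expected step being a 2.5-fold lower number from compound 1 to compound 3 (0.39 log units; beyond the scatter), though a result within the usual scatter would not be surprising. For compound 3 the estimated value in this assay is 20000 nM, with a range from 5000 nM to 80000 nM.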

Compound 3, half-maximal inhibitory concentration: 5400 nM
Compound 3: the middle estimate sits 3.7-fold (0.57 log units) above what was measured; the measured number falls inside the stated range.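

Among the compounds shown here, replacing (3-chloropropyl)amino with chloromethyl on the carbonyl carbon gives the first step that can be read in this assay: a 9.1-fold lower number from compound 1 to compound 3 (0.96 log units; beyond the scatter). This shows that the group at this position matters for the antiproliferative result, and that the full (3-chloropropyl)amino group is not required for activity in this pair, since the smaller chloromethyl group gives the lower number. The data shown offer no explanation for the size of this step, and the one limit among the results does not bear on it.

The change alters several things at once, removing the group's nitrogen with its hydrogen-bond donor and shortening what carries the chlorine, so this single pair cannot separate these features from one another. A plain methyl with no chlorine, a bromomethyl group or a 2-chloroethyl chain on the same carbonyl carbon would each test a different part of the change, and the compounds shown leave open whether the chlorine, the chain length or the lost nitrogen accounts for the step.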